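From compound 2 to compound 3: adding one chloro group

The source may report more compounds than this note shows. Statements on the series, on what has been measured and on what is new or still open speak of the compounds shown alone.

Measured so far in a functional assay on MDA-MB-231 cells (Homo sapiens) for inhibition, read by MTT assay, with a stated time of 48 h; on this read-out lower numbers stand for stronger inhibition of growth and higher numbers for weaker inhibition of growth
Compound 1 `CC(C)(C)c1ccc(Nc2ncnc3ccc(NC(=S)NCc4ccccc4)cc23)cc1` gives 8700 nM
Compound 2 `S=C(Nc1ccccc1)Nc1ccc2ncnc(Nc3cccc(Br)c3)c2c1` gives 10000 nM

Compound 2 at 10000 nM lies within the usual scatter of compound 1 at 8700 nM and so stands level with it. Compound 3 `S=C(Nc1ccc(Cl)cc1)Nc1ccc2ncnc(Nc3cccc(Br)c3)c2c1` differs from compound 2 by chloro in place of hydrogen on an aromatic carbon and has chloro in place of hydrogen on an aromatic carbon, para to a large group. Among the measured compounds shown here, no measured pair shows this change, so only a small step towards stronger inhibition of growth is expected in this assay and possibly none beyond the scatter. The expected move is a 1.5-fold lower number from compound 2 to compound 3 (0.19 log units; within the scatter) on this estimate. Compound 3 is estimated at 6500 nM with a range of 2500 nM to 16000 nM expected.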

Compound 3, concentration for 50% growth inhibition: 8200 nM
The estimate for compound 3 lay 1.3-fold (0.10 log units) below the measured number; measured number inside the range.
By their numbers in this assay, from the lowest: compounds 3, 1 and 2 (each within the scatter of the next).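

On the terminal ring, in this assay, chloro in place of hydrogen on an aromatic carbon, para to a large group, gives a 1.2-fold lower number from compound 2 to compound 3 (0.09 log units; within the scatter). Among the compounds shown here, this is the first single-place comparison, and it shows that the phenyl to 4-chlorophenyl exchange leaves compound 3 level with compound 2. No measurement is available that bears on the reason for this result. On these data alone, whether an amine or a carboxylic acid in place of the chloro would give a step beyond the scatter remains open.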